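A few compounds are considered here, and "the series" means these few. Any claim that something is new, unique, unknown or untested is made for them only; others in the source may bear on it.

Of the compounds shown here, three built on one shared core have been measured in a functional assay on SK-MEL-28 cells (Homo sapiens) for cytotoxicity, read by MTT assay; a higher number here means a weaker inhibitor, a lower number a stronger inhibitor. Compound 1 `O=S(=O)(NCCCNc1nccc(-c2c(-c3cccc(F)c3)nc3sccn23)n1)c1cccc(F)c1` gives 8550 nM. Compound 2 `O=S(=O)(NCCNc1nccc(-c2c(-c3cccc(F)c3)nc3sccn23)n1)c1ccc(Cl)cc1` gives 18600 nM. Compound 3 `O=C(NCCNc1nccc(-c2c(-c3cccc(F)c3)nc3sccn23)n1)c1ccc(Cl)cc1` gives 8160 nM, the lowest of the three numbers, although its gap to compound 1 lies within the scatter and only its gap to compound 2 lies beyond it. The steps among the three are a 2.2-fold higher number from compound 1 to compound 2 (0.34 log units; beyond the scatter), a 1.0-fold lower number from compound 1 to compound 3 (0.02 log units; within the scatter) and a 2.3-fold lower number from compound 2 to compound 3 (0.36 log units; beyond the scatter).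

Compound 4 `Cc1ccc(C(=O)NCCNc2nccc(-c3c(-c4cccc(F)c4)nc4sccn34)n2)cc1` has not yet been measured. It differs from compound 3 by methyl in place of chloro on an aromatic carbon. Among the compounds with values here, none of the measured steps exchanges one substituent for another on the six-membered aromatic ring of carbon only while leaving everything else unchanged: the steps starting from compound 1 change the chain and the attached aryl group together, and the step from compound 2 to compound 3 swaps sulfonyl for carbonyl. Within the data shown here, no measured step therefore bears directly on this change, and with nothing to point either way, the step into compound 4 is expected to be a 1.0-fold higher number from compound 3 to compound 4 (0.02 log units; within the scatter). Compound 4 is accordingly estimated at 8500 nM, with a range from 3000 nM to 25000 nM.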

Compound 4, half-maximal inhibitory concentration: 18800 nM
Compound 4: middle estimate off by 2.2-fold (0.34 log units), on the low side, within the range that was stated.
By their numbers in this assay, from the lowest: compounds 3 and 1 (each within the scatter of the next); then compounds 2 and 4 (each within the scatter of the next).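

In this assay, within the data shown here, methyl in place of chloro on the aromatic carbon is the first change confined to this ring, and it is not neutral: the exchange of one heavy atom for another gives a 2.3-fold higher number from compound 3 to compound 4 (0.36 log units; beyond the scatter). The benefit of carbonyl over sulfonyl seen in a 2.3-fold lower number from compound 2 to compound 3 (0.36 log units; beyond the scatter) therefore holds only with the 4-chlorophenyl group, since the 4-methylphenyl amide shows a 1.0-fold higher number from compound 2 to compound 4 (0.00 log units; within the scatter) and sits level with the sulfonyl compound despite sharing its carbonyl with compound 3. The 4-methylphenyl amide also gives a 2.2-fold higher number from compound 1 to compound 4 (0.34 log units; beyond the scatter), so compound 1 and compound 3 now stand together apart from the other two, and nothing available explains why chloro and methyl differ here.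

From the compounds shown here alone, it remains open whether chloro is the exception at this place or methyl the penalty, which fluoro, methoxy or plain hydrogen on the same ring would help to settle. Going by these compounds, it is equally open whether the same exchange of chloro for methyl would give a step of this size on the sulfonyl compound or with a longer chain.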